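This account rests on a few compounds, and the source may have more. Where it says the series, first, only, none or still open, it means among the compounds named here.

In a functional assay on SK-MEL-2 cells (Homo sapiens) for inhibition (a lower number here means a stronger inhibitor of growth, a higher number a weaker inhibitor of growth), compound 1 `NC(=O)c1cc(Cl)ccc1NC(=O)COc1ccccc1` gives 5080 nM and compound 2 `NC(=O)c1cc(I)ccc1NC(=O)COc1ccccc1` gives 463 nM, the lower of the two numbers. Compound 3 `COc1ccc(NC(=O)COc2ccccc2)c(C(N)=O)c1` has methoxy in place of iodo on an aromatic carbon, para to a large group: methoxy in place of iodo on an aromatic carbon. Among the compounds with values here, the one measured step at this place is large, an 11-fold lower number from compound 1 to compound 2 (1.04 log units; beyond the scatter), with iodo in place of chloro. Going by these compounds, on that step alone, a sizeable move to a higher number is expected in this assay when iodo leaves, though methoxy itself is untested. The estimated step is a 5.4-fold higher number from compound 2 to compound 3 (0.73 log units; beyond the scatter). For compound 3 the estimated value is 2500 nM, with a range of 700 nM to 9000 nM.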

Compound 3, concentration for 50% growth inhibition: 611 nM
Beside the measured number, compound 3's estimate is 4.1-fold (0.61 log units) above it, and the stated range ends above it.
By their numbers in this assay, from the lowest: compounds 2 and 3 (each within the scatter of the next); then compound 1.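

Methoxy for iodo gives a 1.3-fold higher number from compound 2 to compound 3 (0.12 log units; within the scatter) at this place, para to a large group, and methoxy for chloro gives an 8.3-fold lower number from compound 1 to compound 3 (0.92 log units; beyond the scatter) in this assay at the same place. The low number of compound 2 is therefore not unique to iodo, since a group of a different kind, with a hydrogen-bond acceptor, stands level with it. No measurement on hand accounts for chloro standing apart from these two groups.

Going by these compounds, whether an amine or a nitrile here would fall with methoxy and iodo, or with chloro, stays open. So does the outcome for a longer chain such as ethoxy.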